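A few compounds are considered here, and "the series" means these few. Any claim that something is new, unique, unknown or untested is made for them only; others in the source may bear on it.

Working notes on a small series built on one shared core. Compound 1 `CCOC(=O)N1CCN(C(=S)SCC(O)Cn2c([N+](=O)[O-])cnc2C)CC1` carries ethoxycarbonyl on an amine nitrogen in a ring; in a toxicity assay on HeLa cells (Homo sapiens) for cytotoxicity, read by MTT assay, with a stated time of 24 h (on this read-out higher numbers stand for weaker inhibition and lower numbers for stronger inhibition), compound 1 gives 1610000 nM. Compound 2 `COc1ccccc1N1CCN(C(=S)SCC(O)Cn2c([N+](=O)[O-])cnc2C)CC1` carries 2-methoxyphenyl at the same position. In this assay compound 2 reaches only a limit of the assay, > 5000000 nM, so on the numbers shown compound 2 stands as an open range rather than a point. The change from compound 1 to compound 2 gives an at least 3.1-fold higher number from compound 1 to compound 2 (0.49 log units; beyond the scatter); its size is only bounded because of the limit of > 5000000 nM in this assay, at which 1 of the 2 values shown sits.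

Compound 3 `Cc1ncc([N+](=O)[O-])n1CC(O)CSC(=S)N1CCN(c2ncccn2)CC1` is not yet measured. Relative to compound 2 it shows (pyrimidin-2-yl in place of 2-methoxyphenyl on an amine nitrogen in a ring). For the measured compounds named here, the single measured step exchanges ethoxycarbonyl for an aromatic ring, whereas the step to compound 3 exchanges one six-membered aromatic ring for another, so that measured step is a loose guide at best. In this assay the estimate for compound 3 implies a step of an at least 1.2-fold lower number from compound 2 to compound 3 (0.09 log units; that floor lies within the scatter), expected to stay within the scatter. Compound 3 is estimated at 4000000 nM, within 1500000 nM to 10000000 nM, with a real chance that the assay again reports only a limit.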

Compound 3, half-maximal inhibitory concentration: 2040000 nM
Beside the measured number, compound 3's estimate is 2.0-fold (0.29 log units) above it; the measured number falls inside the stated range.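

Within this assay, the position on the amine nitrogen of the six-membered ring now proves sensitive to a change from one six-membered aromatic ring to another: pyrimidin-2-yl in place of 2-methoxyphenyl gives an at least 2.4-fold lower number from compound 2 to compound 3 (0.38 log units; beyond the scatter), so carrying an aromatic ring at this position does not by itself bring a compound to the limit of the assay. The size of that step is bounded on one side only: the limit of > 5000000 nM in this assay, at which 1 of the 3 values shown sits. The new compound also shows that an aromatic ring and a non-aromatic group can read alike at this position, since pyrimidin-2-yl in place of ethoxycarbonyl gives a 1.3-fold higher number from compound 1 to compound 3 (0.10 log units; within the scatter), and the two cannot be told apart in this assay.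

The compounds shown leave open whether the step to pyrimidin-2-yl follows from losing the methoxy group or from the two ring nitrogens entering, a question that plain phenyl at the same position would help to separate. Also open, going by these compounds, is whether a group of another kind on this nitrogen, such as a carboxylic acid or a longer chain ending in an amine, would shift the number in either direction.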